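Benzylic aryl variation on a shared quinazoline-type core, continued

This account rests on a few compounds, and the source may have more. Where it says the series, first, only, none or still open, it means among the compounds named here.

In an assay on a protein complex for inhibition of ubiquitin carboxyl-terminal hydrolase 1/WD repeat-containing protein 48 (Homo sapiens), read by fluorescence (on this read-out higher numbers stand for weaker inhibition and lower numbers for stronger inhibition), compound 1 `FC(F)(F)c1ccccc1-c1nc(NCc2ccc(Cl)c(Cl)c2)c2ccccc2n1` gives 10400 nM. Among the measured compounds shown here, compound 2 `N#Cc1ccc(CNc2nc(-c3ccccc3C(F)(F)F)nc3ccccc23)cc1` gives 5700 nM in this assay, the lower figure of the two measured so far, though the only measured step, a 1.8-fold lower number from compound 1 to compound 2 (0.26 log units; within the scatter), lies within the scatter, so the two numbers cannot be separated. Compound 3 `FC(F)(F)c1ccccc1-c1nc(NCc2ccc(-c3cncnc3)cc2)c2ccccc2n1` differs from compound 2 in one place: pyrimidin-5-yl in place of cyano on an aromatic carbon. For the measured compounds named here, no measured step exchanges a substituent on this ring; the single step from compound 1 to compound 2 replaced the whole aryl group on the saturated chain carbon bound to a nitrogen on an aromatic ring and stayed within the scatter, so it bears only loosely on the new change. With nothing beyond the scatter among the measured pairs, no step beyond the scatter is expected for compound 3 in this assay in either direction. Compound 3 is therefore estimated at 5700 nM, range 1800 nM to 18000 nM. This estimate means an expected step of no change at the digits printed from compound 2 to compound 3 (within the scatter).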

Compound 3, half-maximal inhibitory concentration: 3000 nM
Compound 3: middle estimate off by 1.9-fold (0.28 log units), on the high side; the measured number falls inside the stated range.
By their numbers in this assay, from the lowest: compounds 3, 2 and 1 (each within the scatter of the next, the first and the last beyond it).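

In this assay, among the compounds shown here, the exchange of cyano for pyrimidin-5-yl gives a 1.9-fold lower number from compound 2 to compound 3 (0.28 log units; within the scatter), the first reading of a substituent exchange on this ring. At this aromatic carbon, para to a large group, the 2 heavy atoms of cyano give way to the 6 heavy atoms of a six-membered aromatic ring with 2 hetero atoms, and the step stays within the scatter. Nothing available bears on the reason for this result.

Open, as far as these compounds go, is whether an amine such as morpholine or a carboxylic acid on the same aromatic carbon would give a step beyond the scatter. From the compounds shown here alone, all three compounds also share the trifluoromethyl-substituted aryl group on the shared core, so what that group contributes remains open.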